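Methoxy for chloro on the thioether arm

The compounds below may be only part of what the source reports. "The series", "measured", "known", "first", "only" and "open" are said of these compounds alone.

Of the compounds shown here, three share one core and have been measured. Compound 1 `C#CCNC1CCc2c(OCc3cccc(C(F)(F)F)c3)cccc21` gives 5410 nM in an ADME assay on isolated protein for inhibition of Amine oxidase [flavin-containing] B (Homo sapiens); a higher number here means a weaker inhibitor, a lower number a stronger inhibitor. Compound 2 `C#CCNC1CCc2c(SCCc3ccc(Cl)cc3)cccc21` gives 920 nM in this assay, and compound 3 `C#CCNC1CCc2c(SCc3ccc(C(F)(F)F)cc3)cccc21` gives 930 nM. Compound 2 holds the lowest of the three numbers; compound 3 lies with it within the usual scatter, while the gap to compound 1 lies beyond it. Compound 4 `C#CCNC1CCc2c(SCCc3ccc(OC)cc3)cccc21` is not yet measured; it differs from compound 2 by methoxy in place of chloro on an aromatic carbon. For the measured compounds named here, no measured pair shows this change, so no step size can be read from the data. The step is expected to be a 1.5-fold higher number from compound 2 to compound 4 (0.18 log units; within the scatter), a modest move toward a higher number that may not exceed the scatter. Compound 4 is estimated at 1400 nM, with a range from 500 nM to 4000 nM.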

Compound 4, half-maximal inhibitory concentration: 4590 nM
Compound 4: middle estimate off by 3.3-fold (0.52 log units), on the low side; measured number above the stated range.
By their numbers in this assay, from the lowest: compounds 2 and 3 (each within the scatter of the next); then compounds 4 and 1 (each within the scatter of the next).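

In this assay, for the compounds shown here, methoxy in place of chloro gives a 5.0-fold higher number from compound 2 to compound 4 (0.70 log units; beyond the scatter) and this is the first single-place step. It shows that this place, para to a large group, is sensitive to the substituent: 4-chlorophenyl cannot be swapped for 4-methoxyphenyl without a clear loss. Nothing at hand accounts for the size of this step.

Still open, going by these compounds, is how a fluoro, methyl or hydroxyl group would read at this place. Also open, on these data alone, is whether methoxy would carry the same cost on a shorter chain.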